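The compounds below may be only part of what the source reports. "The series", "measured", "known", "first", "only" and "open" are said of these compounds alone.

Compound 1 `COc1cc(C(=O)/C=C/c2ccc(OCCCC(=O)NCCCCN(CCCN)CCCCN)cc2)cc(OC)c1OC` carries the ((4-aminobutyl)(3-aminopropyl)amino)methyl chain on its amide, and in a functional assay on DU-145 cells (Homo sapiens) for antiproliferative activity, read by MTT assay, with a stated time of 48 h (on this read-out lower numbers stand for stronger inhibition and higher numbers for weaker inhibition), compound 1 gives 86800 nM. Compound 2 `COc1cc(C(=O)/C=C/c2ccc(OCCCC(=O)NCCCNCCCCN)cc2)cc(OC)c1OC` differs from it in one place: (4-aminobutyl)amino in place of ((4-aminobutyl)(3-aminopropyl)amino)methyl on a saturated chain carbon, three bonds along the chain from an amide-type nitrogen. In this assay compound 2 reaches only a limit, > 100000 nM, one of the values that sit at the limit of > 100000 nM in this assay, at which 1 of the 3 values shown sits. The step reads an at least 1.1-fold higher number from compound 1 to compound 2 (0.06 log units; that floor lies within the scatter). Compound 3 `COc1ccc(/C=C/C(=O)c2cc(OC)c(OC)c(OC)c2)cc1OCCCC(=O)NCCCCN(CCCN)CCCCN` keeps the longer chain on another core; the difference between the two cores is not broken down here. In this assay compound 3 gives 82300 nM, which against compound 1 lies within the scatter. Compound 4 `COc1ccc(/C=C/C(=O)c2cc(OC)c(OC)c(OC)c2)cc1OCCCC(=O)NCCCNCCCCN` is not yet measured and stands to compound 3 as compound 2 stands to compound 1: (4-aminobutyl)amino in place of ((4-aminobutyl)(3-aminopropyl)amino)methyl on a saturated chain carbon, three bonds along the chain from an amide-type nitrogen. The place is the same in both pairs, so this is the same change on the other core. For compound 4 the expected step in this assay is a 1.5-fold higher number from compound 3 to compound 4 (0.16 log units; within the scatter), resting on compound 3 at 82300 nM and on the measured step of an at least 1.1-fold higher number from compound 1 to compound 2 (0.06 log units; that floor lies within the scatter). Compound 4 is estimated at 120000 nM, with a range from 60000 nM to 250000 nM, and a limit rather than a number is the likelier outcome.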

Compound 4, half-maximal inhibitory concentration: > 100000 nM
Compound 4 ended at the assay's limit; the forecaster's own chance of this, stated with the estimate: 60%; the middle value lies beyond the limit too.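

In this assay compound 4 gives > 100000 nM as a limit of the assay, not a number. Going by these compounds, the step is an at least 1.2-fold higher number from compound 3 to compound 4 (0.08 log units; that floor lies within the scatter) and so gives only a floor: on this core, as on the core of compound 1, the exchange of ((4-aminobutyl)(3-aminopropyl)amino)methyl for (4-aminobutyl)amino ends at the limit, while the true size of the change stays unknown on both cores. The change therefore leads to the same limit on both cores, but whether it carries over with the same size cannot be said: the same change on two cores in this assay, an at least 1.1-fold higher number (0.06 log units; that floor lies within the scatter) from compound 1 to compound 2 and an at least 1.2-fold higher number (0.08 log units; that floor lies within the scatter) from compound 3 to compound 4; the limit leaves it open whether they differ.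

The compounds shown leave open how a longer chain, such as a polyamine with a further aminopropyl arm, or a single terminal amine on the amide would read in this assay. They also leave open any actual size for this change, since the read-out gives no number for the compounds with the (4-aminobutyl)amino chain: the limit of > 100000 nM in this assay, at which 2 of the 4 values shown sit.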